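A hydroxy group enters a series that barely inhibits

The source may hold more compounds than are shown below. What is called first, only, known or untested is meant among the compounds shown, and "the series" means these compounds.

The study measured antiproliferative activity in a functional assay on DU-145 cells (Homo sapiens) for antiproliferative activity, read by MTT assay, with a stated time of 24 h; on this read-out lower numbers stand for stronger inhibition and higher numbers for weaker inhibition. Compound 1 `c1ccc(-c2noc(-c3ccncc3)n2)cc1` gives 657000 nM in this assay. Compound 2 `COc1ccc(-c2noc(-c3ccccc3)n2)cc1OC1CCCC1` returns only a limit of the assay, > 1000000 nM, and no number. Compound 3 `COc1ccc(-c2noc(-c3ccc(F)cc3)n2)cc1O` likewise returns only a limit, > 1000000 nM. Compound 2 thus sits at the boundary shared by two of the three values shown (the limit of > 1000000 nM in this assay, at which 2 of the 3 values shown sit). The unmeasured compound 4 `COc1ccc(-c2noc(-c3ccc(O)cc3)n2)cc1OC1CCCC1` differs from compound 2 by hydroxy in place of hydrogen on an aromatic carbon. Going by the values given here, no measured pair in this set isolates such a change, so no step size can be read from the data; no shift beyond the scatter is expected. The step from compound 2 to compound 4 is estimated as an at least 1.1-fold lower number from compound 2 to compound 4 (0.04 log units; that floor lies within the scatter). Compound 4 is expected to give about 900000 nM, within 400000 nM to 2000000 nM, quite possibly again only as a limit.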

Compound 4, half-maximal inhibitory concentration: 780 nM
For compound 4 the middle estimate is 1200-fold (3.06 log units) above the measured one; the whole stated range lies above it.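

Going by these compounds alone, changing phenyl to 4-hydroxyphenyl gives an at least 1200-fold lower number from compound 2 to compound 4 (3.10 log units; beyond the scatter), so this one position, para to a large group, can carry a very large change in antiproliferative activity, which no earlier pair could show. The step is only a floor, since the value of compound 2 is a limit and not a number: the limit of > 1000000 nM in this assay, at which 2 of the 4 values shown sit.

The compounds shown do not tell whether a methoxy group, an amine or a carboxylic acid at this position would match hydroxy. They also leave open whether the same change would act alike on the other compounds.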